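The source may report more compounds than this note shows. Statements on the series, on what has been measured and on what is new or still open speak of the compounds shown alone.

Compound 1 `COc1cc2c(Nc3nc4ccc(C(=O)Nc5c(C)cccc5C)cc4s3)ncnc2cc1OCCCN1CCCC1`, compound 2 `CCN(CC)CCCOc1cc2ncnc(Nc3nc4ccc(C(=O)Nc5c(C)cccc5C)cc4s3)c2cc1OC` and compound 3 `COc1cc2c(Nc3nc4ccc(C(=O)Nc5c(C)cccc5C)cc4s3)ncnc2cc1OCCCN1CCCCC1` share one core and differ only in the amine at the end of the chain. In a functional assay on NCI-H661 cells (Homo sapiens) for cytotoxicity, read by WST assay, with a stated time of 72 h (a lower number here means a stronger inhibitor, a higher number a weaker inhibitor), compound 2 gives 66500 nM. Compound 1 reaches only the limit of this assay, > 100000 nM. Compound 3 likewise reaches only a limit, > 100000 nM, so its standing among the three is known only as a bound. Two of the three values sit there (the limit of > 100000 nM in this assay, at which 2 of the 3 values shown sit). Compound 4 `COc1cc2c(Nc3nc4ccc(C(=O)Nc5c(C)cccc5C)cc4s3)ncnc2cc1OCCCN1CCCCC1C` carries methyl in place of hydrogen on a saturated ring carbon. The steps of an at least 1.5-fold lower number from compound 1 to compound 2 (0.17 log units; that floor lies within the scatter) and an at least 1.5-fold higher number from compound 2 to compound 3 (0.17 log units; that floor lies within the scatter) are floors within the scatter, and a step that the two limits leave unreadable from compound 1 to compound 3. Nothing read here suggests a move beyond the scatter, so compound 4 is expected to sit again near the limit, a number no higher from compound 3 to compound 4 (the limit leaves the size open), and its estimate is 100000 nM with a range from 50000 nM to 300000 nM.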

Compound 4, half-maximal inhibitory concentration: 84400 nM
For compound 4 the middle estimate is 1.2-fold (0.07 log units) above the measured one; the range from low to high includes it.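

In this assay, methyl on the saturated ring carbon turns a limit into a measured number, yet the change shows only an at least 1.1-fold lower number from compound 3 to compound 4 (0.07 log units; that floor lies within the scatter). Replacing pyrrolidin-1-yl with 2-methylpiperidin-1-yl gives an at least 1.1-fold lower number from compound 1 to compound 4 (0.07 log units; that floor lies within the scatter), while replacing diethylamino with it gives a 1.3-fold higher number from compound 2 to compound 4 (0.10 log units; within the scatter), so no amine here stands apart from the others. Two of these steps remain floors because they start from limits: the limit of > 100000 nM in this assay, at which 2 of the 4 values shown sit.

On these data alone, whether a morpholin-4-yl or 4-methylpiperazin-1-yl group at the chain end, or a longer chain, would move the number beyond the scatter stays open.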